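Nitroimidazole acylhydrazones: cytotoxicity, methoxy variant

The compounds below may be only part of what the source reports. "The series", "measured", "known", "first", "only" and "open" are said of these compounds alone.

Two members of the series have been through an ADME assay on HepG2 cells (Homo sapiens) for cytotoxicity, read by MTT assay, with a stated time of 48 h (a higher number here means a weaker inhibitor, a lower number a stronger inhibitor), so far. Compound 1 `Cc1ccc(/C=N/NC(=O)Cn2c([N+](=O)[O-])cnc2C)cc1` sits at a limit of that assay: in this assay compound 1 gives > 100000 nM, a limit and not a number. Among the measured compounds shown here, compound 2 `Cc1ncc([N+](=O)[O-])n1CC(=O)N/N=C/c1ccccc1`, the unsubstituted parent of the pair, has in this assay only "not determined" (no result reported), so no single number stands for it; the one further value in the set is the limit of > 100000 nM in this assay, at which 1 of the 2 values shown sits.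

Compound 3 `COc1ccc(/C=N/NC(=O)Cn2c([N+](=O)[O-])cnc2C)cc1` differs from compound 2 by methoxy in place of hydrogen on an aromatic carbon. For the measured compounds named here, no step between measured compounds exists to set a size for this change, and in this assay no shift beyond the usual scatter is expected in either direction. For compound 3 the estimate in this assay is 100000 nM, with a range from 30000 nM to 300000 nM, most probably reported again only as a limit.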

Compound 3, half-maximal inhibitory concentration: > 100000 nM
Compound 3 was reported as a limit; the forecaster's own chance of this, stated with the estimate: 70%; the middle value lies on the limit itself.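

Compound 1 and compound 3 both stand as limits in this assay, so no step can be read between them: the limit of > 100000 nM in this assay, at which 2 of the 3 values shown sit.

The compounds shown leave open whether methoxy in place of methyl on an aromatic carbon shifts the read-out at all, since neither compound has a single number.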